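The source may report more compounds than this note shows. Statements on the series, on what has been measured and on what is new or still open speak of the compounds shown alone.

The shared core is that of compound 1 `CCc1ccc2oc(CSc3nnc(CNc4ccccc4)n3CC)nc2c1`, for which the result in an ADME assay on blood (Rattus norvegicus) for metabolic stability, with a stated time of 2 h (a lower number here means that less of the compound is left, a higher number that more of the compound is left), stands as "not determined" (no result reported). Compound 2 `CCC(=O)c1ccc2oc(CS(=O)(=O)c3nnc(CNc4ccccc4)n3CC)nc2c1` gives 44% in this assay. Among the compounds with values here, compound 3 `CCn1c(CNc2ccccc2)nnc1SCc1nc2cc(OC(F)(F)F)ccc2o1` gives 100% in this assay, the highest of the two numbers measured so far, and compound 2 sits well below it, beyond the scatter.

The step to compound 4 `CCC(O)c1ccc2oc(CSc3nnc(CNc4ccccc4)n3CC)nc2c1` is a single change: 1-hydroxypropyl in place of trifluoromethoxy on an aromatic carbon. Compound 4 thus carries a 1-hydroxypropyl group where compound 3 carries trifluoromethoxy, with the rest of the structure unchanged. Within the data shown here, no step between two measured compounds tells how much a change of this kind moves this assay. Compound 2, which also lacks trifluoromethoxy, gives 44% in this assay, though it differs from compound 3 in more than one place, so its number speaks only loosely for compound 4.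

Compound 3 gives 100%, which leaves no room upward, so the step in this assay is expected to go downward, a number 30 percentage points lower from compound 3 to compound 4 (beyond the scatter), beyond the scatter. For compound 4 the expected value in this assay is 70%, with a range from 40% to 100%.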

Compound 4, percent of the compound remaining: 80%
The estimate for compound 4 lay 10 percentage points below the measured number, within the range that was stated.
By their numbers in this assay, from the lowest: compound 2; then compound 4; then compound 3.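

In this assay, within the data shown here, replacing trifluoromethoxy with 1-hydroxypropyl on an aromatic carbon gives a number 20 percentage points lower from compound 3 to compound 4 (beyond the scatter), the only step here between measured compounds that differ in one place, and it shows that this position does bear on the read-out. The change is a modest one, and compound 4 , with a group that carries a hydrogen-bond donor where trifluoromethoxy carries none, still stands at 80%, so this exchange at the position, on a six-membered aromatic ring of carbon only, leaves much of the compound remaining after the stated time. Nothing measured here ties this step to any property of either group.

Going by these compounds, it stays open how a plain propyl chain, an amine or a carboxylic acid on this same aromatic carbon would stand in this assay, and so whether the step follows the hydroxyl group or the carbon chain. Also open, on these data alone, is whether a step of this size would hold for the same exchange in other compounds, as a single pair shows no pattern.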